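The compounds below may be only part of what the source reports. "The series", "measured", "known", "first", "only" and "open" are said of these compounds alone.

Compound 1 `CN1c2ccc(NC(=O)Nc3ccc([N+](=O)[O-])cc3)cc2C(C)(C)C(=O)C1(C)C`: 300 nM in an assay on isolated protein for binding affinity to stress-70 protein, mitochondrial (Homo sapiens); a higher number here means weaker binding, a lower number tighter binding. Compound 2 `CN1c2ccc(NC(=O)Nc3ccc(OC(F)(F)F)cc3)cc2C(C)(C)C(=O)C1(C)C`: 1800 nM.

Compound 2 gives the higher of the two numbers, the other being compound 1, since a 6.0-fold higher number from compound 1 to compound 2 (0.78 log units; beyond the scatter). Compound 3 `CN1c2ccc(NC(=O)Nc3ccc(N)cc3)cc2C(C)(C)C(=O)C1(C)C` carries amino in place of trifluoromethoxy on an aromatic carbon. The only measured step at this position, a 6.0-fold higher number from compound 1 to compound 2 (0.78 log units; beyond the scatter), shows that changing this group can move the number modestly and beyond the scatter; whether an amino group pulls it back toward compound 1 or pushes it further is not shown. A step of a 1.2-fold lower number from compound 2 to compound 3 (0.08 log units; within the scatter) is therefore expected, close to no change. The estimate for compound 3 is 1500 nM, within 400 nM to 6000 nM.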

Compound 3, dissociation constant: 1100 nM
Compound 3: middle estimate off by 1.4-fold (0.13 log units), on the high side; low and high end bracket the measured number.
By their numbers in this assay, from the lowest: compound 1; then compounds 3 and 2 (each within the scatter of the next).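

In this assay, amino in place of trifluoromethoxy gives a 1.6-fold lower number from compound 2 to compound 3 (0.21 log units; within the scatter) so these two groups cannot be told apart at this position. Amino in place of nitro gives a 3.7-fold higher number from compound 1 to compound 3 (0.56 log units; beyond the scatter) so compound 1, with its nitro group, now stands apart from both other compounds, not from compound 2 alone. Nothing measured here explains this difference.

Still open, on these data alone, is how a nitrile, a carboxylic acid or a methoxy group would compare with nitro at this position. As far as these compounds go, whether any group here can give a lower number than nitro also remains unknown.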